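The source may hold more compounds than are shown below. What is called first, only, known or untested is meant among the compounds shown, and "the series" means these compounds.

Compound 1 `COc1cc(CSc2ccc3c(C)cc(=O)oc3c2)c([N+](=O)[O-])cc1OC` gives > 25800 nM in a functional assay on KBVIN cells (Homo sapiens) for antiproliferative activity, read by sulforhodamine B assay, with a stated time of 72 h; a higher number here means a weaker inhibitor of growth, a lower number a stronger inhibitor of growth; this is a limit of the assay and not a number.
Compound 2 `CCc1cc(=O)c2ccc(OCc3cccc(C(F)(F)F)c3)c(C)c2o1` gives > 27600 nM in this assay, again a limit and not a number.
Compound 3 `CCc1oc2c(C)c(OC)ccc2c(=O)c1Br` gives 23200 nM in this assay.

Among these three, compound 3 is the only one with an actual number; the other two reached only the ceiling of the measurement, as the limit of > 25800 nM in this assay, at which 1 of the 3 values shown sits, and the limit of > 27600 nM in this assay, at which 1 of the 3 values shown sits, record. For the measured compounds named here, no pair of measured compounds here differs in a single place, so nothing can be read off about how one change shifts the result.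

Compound 4 `CCc1oc2c(C)c(OC(C)C)ccc2c(=O)c1Br` is the unmeasured partner of compound 3. The change is isopropyl in place of methyl on an oxygen on an aromatic ring. Going by the values given here, nothing among the measured compounds shows what such a swap does in this assay, so the expected step from compound 3 to compound 4 is none beyond the usual scatter, in either direction, as a 1.1-fold lower number from compound 3 to compound 4 (0.02 log units; within the scatter) expresses. For compound 4 the estimate in this assay is therefore 22000 nM, with a plausible range from 8000 nM to 60000 nM; a result that is again only a limit would not be surprising.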

Compound 4, concentration for 50% growth inhibition: 5840 nM
For compound 4 the middle estimate is 3.8-fold (0.58 log units) above the measured one; the measured number lies below the stated range.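

For the compounds shown here, the swap of methoxy to isopropoxy is the first change at a single place that can be read, and it gives a 4.0-fold lower number from compound 3 to compound 4 (0.60 log units; beyond the scatter) in this assay. It shows that growth inhibition at this position responds to what sits on the oxygen, something compounds 1, 2 and 3 could not show because none of them differs from another in one place only. Here isopropyl, the larger group by heavy atoms, is not merely accepted in place of methyl but comes with stronger inhibition, although this is one pair and not yet a trend. The limits recorded for compounds 1 and 2 have no bearing on this step, and nothing measured here explains why the swap has this effect.

Going by these compounds, it remains open whether the number keeps falling with a longer chain on the same oxygen, such as butyl, or with a ring such as cyclopentyl, and whether a chain ending in an amine or a carboxylic acid would be accepted there. Also open, on these data alone, is whether the same swap would have a similar effect with another group in place of the bromine of compound 4.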